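The compounds below may be only part of what the source reports. "The series", "measured", "known", "first", "only" and "open" are said of these compounds alone.

Three compounds have been measured in a functional assay on the whole organism (strain albino) for inhibition, with Rattus norvegicus as the target, read by paw edema, with a stated time of 4 h, at a dose of 0.28 mmol/kg by the oral route; on this read-out higher numbers stand for more inhibition at the one dose given (going by the name of the read-out) and lower numbers for less inhibition:

compound 1, `COc1ccc(-c2nnc(SC/C(=N/O)c3ccccc3)n2-c2ccccc2)cc1`, gives 80%
compound 2, `CCn1c(SCC(=O)c2ccccc2)nnc1-c1ccc(OC)cc1`, gives 70%
compound 3, `O/N=C(/CSc1nnc(-c2ccccc2)n1-c1ccccc1)c1ccccc1`, gives 79%

Compound 1 and compound 3 differ in one place only, (hydrogen in place of methoxy on an aromatic carbon). In this assay this change made a step of a number 1 percentage points lower from compound 1 to compound 3 (within the scatter), so the two numbers sit within the usual scatter of repeated measurements and cannot be told apart.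

Compound 2 has a different core from compound 1; the difference between the two cores is not broken down here. The number for compound 2 lies within the scatter of the number for compound 3 and also within the scatter of the number for compound 1, so no order among the three can be drawn from these values.

Compound 4, `CCn1c(SCC(=O)c2ccccc2)nnc1-c1ccccc1`, has not yet been measured. It is related to compound 2 by hydrogen in place of methoxy on an aromatic carbon. This is the same change that links compound 1 to compound 3, made at the same kind of place on the same kind of ring. Since that earlier change produced a step of a number 1 percentage points lower from compound 1 to compound 3 (within the scatter) in compound 1, the step from compound 2 to compound 4 is expected to be of similar size, about a number 1 percentage points lower from compound 2 to compound 4 (within the scatter) in this assay. On that basis compound 4 is estimated to give about 69% in this assay, most likely somewhere between 56% and 82%.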

Compound 4, a percentage reported as inhibition, in the whole organism at one dose (the size of the read-out at that dose, not a potency): 63%
For compound 4 the middle estimate is 6 percentage points above the measured one; the range from low to high includes it.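

Removing the methoxy group from the core of compound 2 in this assay gives a number 7 percentage points lower from compound 2 to compound 4 (within the scatter) and so cannot be told apart from what repeated measurements of a single compound would give. Set beside the earlier step on the other core, this step agrees with it as far as these numbers can tell: the same change on two cores in this assay, a number 1 percentage points lower (within the scatter) from compound 1 to compound 3 and a number 7 percentage points lower (within the scatter) from compound 2 to compound 4, 6 percentage points apart, within the scatter of two such steps. On these two cores, then, the change from 4-methoxyphenyl to phenyl carries over as a step too small to read, but this does not show that the two steps are truly equal or that the methoxy group makes no difference, as a small real effect could stay hidden in the scatter and a single dose gives the size of the read-out rather than a potency.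

The compounds shown leave open whether another group at that same place on the ring, such as an amine, a carboxylic acid or a chlorine atom, would give a step beyond the scatter. They also leave open whether a longer chain in place of the ethyl group of compound 2 and compound 4 would give a number that can be told apart from theirs.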